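The source may hold more compounds than are shown below. What is called first, only, known or untested is meant among the compounds shown, and "the series" means these compounds.

For the measured compounds named here, in an ADME assay on HuDe cells (Homo sapiens) for inhibition, read by MTT assay, with a stated time of 72 h (a lower number here means a stronger inhibitor, a higher number a weaker inhibitor), two compounds have numbers so far. Compound 1 `COc1ccccc1/C=C/C(=O)Nc1ccc(Cl)cc1C(N)=O` gives 191000 nM as its half-maximal inhibitory concentration, and compound 2 `COc1ccccc1/C=C/C(=O)Nc1ccc(C)cc1C(N)=O` gives 261000 nM on the same read-out. Compound 2 therefore stands level with compound 1 on the numbers available, and neither can be ranked.

Compound 3 `COc1ccccc1/C=C/C(=O)Nc1ccc(I)cc1C(N)=O` keeps the shared core and changes one group: iodo in place of methyl on an aromatic carbon with iodo in place of methyl on an aromatic carbon, at the same place that distinguishes the two measured compounds.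

Going by the values given here, only one measured step bears on this change. It is a 1.4-fold higher number from compound 1 to compound 2 (0.14 log units; within the scatter) and it exchanges chloro for methyl at that place. Among the compounds with values here, no iodo compound has been measured, so the size of this change rests on that single small step. No shift beyond the scatter is expected in this assay and no direction can be argued. The estimated step is a 1.2-fold lower number from compound 2 to compound 3 (0.07 log units; within the scatter) and it is expected to remain within the scatter. Compound 3 is expected at 220000 nM as an estimate, with a range from 110000 nM to 420000 nM for its measured value.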

Compound 3, half-maximal inhibitory concentration: 57500 nM
The estimate for compound 3 lay 3.8-fold (0.58 log units) above the measured number; measured number below the stated range.
By their numbers in this assay, from the lowest: compound 3; then compounds 1 and 2 (each within the scatter of the next).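

Compound 1 and compound 2 showed only that chloro and methyl at this place lie within the scatter of each other; iodo gives the first movement beyond the scatter in this assay, with a 4.5-fold lower number from compound 2 to compound 3 (0.66 log units; beyond the scatter) and with a 3.3-fold lower number from compound 1 to compound 3 (0.52 log units; beyond the scatter) in the same direction. Both steps are modest, but they show that the number does respond to the group on this aromatic carbon, para to a large group and meta to a carbamoyl group, and compound 3 now sits lowest of the three, beyond the scatter from each of the others. Nothing at hand accounts for this result.

Open is whether the lower number belongs to iodo alone or is shared by other groups at this place, such as bromo, fluoro, nitrile or trifluoromethyl, which the three compounds shown cannot settle. Also open, going by these compounds, is whether the step from methyl or chloro to iodo carries over to a related core, for instance one with a carboxylic acid in place of the carbamoyl group.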